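A few compounds are considered here, and "the series" means these few. Any claim that something is new, unique, unknown or untested is made for them only; others in the source may bear on it.

Measured compounds:
compound 1 `CN(c1cc2ncc(=O)[nH]c2cc1Nc1nc(-c2ccccc2)cs1)C1CCCCC1` — 62500 nM
compound 2 `CN(c1cc2ncc(=O)[nH]c2cc1Nc1nc(-c2cccc3ccccc23)cs1)C1CCCCC1` — 57400 nM
compound 3 `CN(c1cc2ncc(=O)[nH]c2cc1Nc1nc(-c2cccs2)cs1)C1CCCCC1` — 71300 nM

The three compounds share one core and differ only in the aryl group carried on the thiazole. In an ADME assay on Huh-7 cells (Homo sapiens) for cytotoxicity (on this read-out higher numbers stand for weaker inhibition and lower numbers for stronger inhibition), compound 1 gives 62500 nM, the second highest of the three numbers, although every gap to the others lies within the scatter: the step of a 1.1-fold lower number from compound 1 to compound 2 (0.04 log units; within the scatter) and the step of a 1.1-fold higher number from compound 1 to compound 3 (0.06 log units; within the scatter) are both small, as is a 1.2-fold higher number from compound 2 to compound 3 (0.09 log units; within the scatter). Nothing in this set separates the three compounds in this assay.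

Compound 4 `CN(c1cc2nc(Cc3ccccc3)c(=O)[nH]c2cc1Nc1nc(-c2ccccc2)cs1)C1CCCCC1` is not yet measured. It arises from compound 1 by benzyl in place of hydrogen on an aromatic carbon, the benzyl sitting on the core rather than on the thiazole aryl. Within the data shown here, none of the measured steps touches that place, so none bears directly on the change; they only show that swapping the aryl on the thiazole leaves this assay unmoved. On that basis no step beyond the scatter is expected from compound 1 to compound 4, with the estimated step being a 1.0-fold lower number from compound 1 to compound 4 (0.02 log units; within the scatter). Compound 4 is therefore expected to give about 60000 nM, in a range from 25000 nM to 150000 nM.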

Compound 4, half-maximal inhibitory concentration: 42000 nM
Compound 4: the middle estimate sits 1.4-fold (0.15 log units) above what was measured; the range from low to high includes it.
By their numbers in this assay, from the lowest: compounds 4, 2, 1 and 3 (each within the scatter of the next).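

Among these compounds, compound 4 is the only one of the four compounds with a group on the shared core rather than on the thiazole aryl, so it gives the first reading at this aromatic carbon, next to the ring nitrogen. In this assay, benzyl in place of hydrogen there gives a 1.5-fold lower number from compound 1 to compound 4 (0.17 log units; within the scatter), so this change, like the swaps of the thiazole aryl among phenyl, naphthalen-1-yl and thiophen-2-yl, does not separate the compounds. No supporting measurement is available to explain where this value falls.

The compounds shown leave open whether this position would stay as unresponsive with a group other than benzyl, such as a methyl, an amine or a carboxylic acid, since benzyl is the only group seen on this carbon. They also leave open whether benzyl here would read the same alongside naphthalen-1-yl or thiophen-2-yl on the thiazole, since it appears only with phenyl.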